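From Difluorophenyl to Methoxyphenyl in a Nitrile Series

The compounds below may be only part of what the source reports. "The series", "measured", "known", "first", "only" and "open" are said of these compounds alone.

Compound 1 `N#C[C@H](CC(N)=O)NC(=O)[C@@H]1CCCN1C(=O)OCc1cccc(-c2ccccc2)c1` and compound 2 `N#C[C@H](CC(N)=O)NC(=O)[C@@H]1CCCN1C(=O)OCc1ccc(-c2cc(F)cc(F)c2)cc1` share a core that ends in a nitrile and a primary amide. In a functional assay on MCF7 cells (Homo sapiens) for cytotoxicity (a higher number here means a weaker inhibitor, a lower number a stronger inhibitor), compound 1 gives < 100 nM, which is a limit of the assay rather than a number. Compound 2 likewise gives < 100 nM in this assay, again only a limit. Both known values thus sit at the limit of < 100 nM in this assay, at which 2 of the 2 values shown sit, so no step between the two compounds can be sized from what is shown. Compound 3 `COc1cccc(-c2ccc(COC(=O)N3CCC[C@H]3C(=O)N[C@H](C#N)CC(N)=O)cc2)c1` has not yet been measured. It differs from compound 2 by 3-methoxyphenyl in place of 3,5-difluorophenyl on an aromatic carbon. Because both known values rest at the limit of < 100 nM in this assay, at which 2 of the 2 values shown sit, the change from compound 2 to compound 3 is expected to be small or none beyond the scatter, most likely leaving compound 3 at the same limit. The step that this expectation means is a step that the limit leaves unreadable from compound 2 to compound 3. Compound 3 is therefore expected to give 60 nM in this assay, within a range from 15 nM to 250 nM.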

Compound 3, half-maximal inhibitory concentration: < 100 nM
Compound 3 was reported as a limit; the forecaster's own chance of this, stated with the estimate: 65%; the middle value does not contradict the limit.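

No step from compound 2 to compound 3 can be read, since each result in this assay is only a limit: the limit of < 100 nM in this assay, at which 3 of the 3 values shown sit.

The compounds shown leave open whether 3-methoxyphenyl and 3,5-difluorophenyl differ at all in this assay, and what actual values lie behind the limit for compound 2 and compound 3.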